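Chloro for Methyl in a Free Fatty Acid Receptor Series

The source may hold more compounds than are shown below. What is called first, only, known or untested is meant among the compounds shown, and "the series" means these compounds.

Of the compounds shown here, three have been measured in a functional assay on cells for agonist activity at Free fatty acid receptor 1 (Mus musculus), read by FLIPR and calcium flux, with a stated time of 100 s; on this read-out lower numbers stand for an effect already at smaller amounts and higher numbers for an effect only at larger amounts of compound. Compound 1 `Cc1ccc(Oc2ccc(N3CCC[C@H]3CC(=O)O)cc2)cc1` gives > 33000 nM, which is a limit of this assay rather than a number. Compound 2 `O=C(O)C[C@@H]1CCCN1c1ccc(Oc2ccc(Cl)cc2)cc1` likewise reaches only the limit of > 33000 nM. The change between them, (chloro in place of methyl on an aromatic carbon), accordingly makes a step that the two limits leave unreadable from compound 1 to compound 2. Compound 3 `Cc1cccc(Oc2ccc(N3C[C@@H](C(F)(F)F)C[C@H]3CC(=O)O)cc2)c1C` is the only one of the three with a number, 500 nM. How the core of compound 3 differs from that of compound 1 is not broken down here. The same kind of change now leads to compound 4 `Cc1c(Cl)cccc1Oc1ccc(N2C[C@@H](C(F)(F)F)C[C@H]2CC(=O)O)cc1`: chloro in place of methyl on an aromatic carbon. The surroundings differ, though: in compound 1 the carbon sits para to a large group, whereas in compound 3 it sits ortho to a methyl group and meta to a large group. Because the limit of > 33000 nM in this assay, at which 2 of the 3 values shown sit, leaves the first step unreadable, the earlier pair gives no measure of its size. For compound 4 a step of no change at the digits printed from compound 3 to compound 4 (within the scatter) is expected, resting on compound 3 and its measured 500 nM. Compound 4 is thus estimated at 500 nM, between 150 nM and 1700 nM.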

Compound 4, half-maximal effective concentration: 430 nM
Beside the measured number, compound 4's estimate is 1.2-fold (0.07 log units) above it, and the stated range covers the measured number.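

In this assay, chloro in place of methyl on the core of compound 3, read as 2,3-dimethylphenoxy to 3-chloro-2-methylphenoxy, gives a 1.2-fold lower number from compound 3 to compound 4 (0.07 log units; within the scatter), so on this core the exchange leaves the read-out where it was. The same exchange on the core of compound 1 cannot be read, as compound 1 and compound 2 both stand at a limit rather than at a number: the limit of > 33000 nM in this assay, at which 2 of the 4 values shown sit. From the compounds shown here alone, the series therefore offers a single readable pair, which shows that the change is tolerated on one core but does not show that it behaves alike on another core, so carrying it across remains untested by these data.

The compounds shown leave open what fluoro, methoxy or a nitrile would give at the same aromatic carbon on the core of compound 3. They also leave open whether the result would hold with hydrogen in place of the methyl group that stays on the ring, or with a longer chain carrying the carboxylic acid.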